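Fluoro to methyl swap on the fused ring of compound 1

The source may hold more compounds than are shown below. What is called first, only, known or untested is meant among the compounds shown, and "the series" means these compounds.

Of the compounds shown here, two have numbers so far. Compound 1 `Nc1nccc(-c2ccc3nc(C4COc5ccc(F)cc5C4)oc3c2)n1` gives 15 nM in an assay on isolated protein for inhibition of Rho-associated protein kinase 2 (Homo sapiens); a higher number here means a weaker inhibitor, a lower number a stronger inhibitor. Compound 2 `Cc1[nH]ncc1-c1ccc2nc(C3COc4ccccc4C3)oc2c1` gives 9 nM in this assay. The two values lie within the usual scatter of each other, so compound 1 is not set apart from compound 2 on the numbers at hand. Compound 3 `Cc1ccc2c(c1)CC(c1nc3ccc(-c4ccnc(N)n4)cc3o1)CO2` has not been measured yet. It differs from compound 1 in one place: methyl in place of fluoro on an aromatic carbon. Among the compounds with values here, no measured pair shows this exchange, so there is no step to lean on. The change is small as counted, with no donor, acceptor or charge altered. The expected step of no change at the digits printed from compound 1 to compound 3 (within the scatter) is therefore none beyond the scatter, in either direction. Compound 3 is estimated at 15 nM in this assay, with a range of 6 nM to 40 nM.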

Compound 3, half-maximal inhibitory concentration: 78 nM
Compound 3: middle estimate off by 5.2-fold (0.72 log units), on the low side, outside the stated range (above it).
By their numbers in this assay, from the lowest: compounds 2 and 1 (each within the scatter of the next); then compound 3.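

In this assay the position on the aromatic carbon of the fused system proves sensitive: methyl in place of fluoro gives a 5.2-fold higher number from compound 1 to compound 3 (0.72 log units; beyond the scatter). Within the data shown here, the exchange swaps one heavy atom for one heavy atom and alters no donor, acceptor or charge, so even a change this small on this carbon is enough to move the number beyond the scatter, and the earlier compounds held no pair to show this. No measured evidence on the two groups bears on why the number rises.

This rests on a single pair on the core of compound 1, so the reading may not carry over to other compounds of the series. Open, from the compounds shown here alone, is whether a plain hydrogen on this carbon reads closer to fluoro or to methyl, and how chloro, methoxy or an amine would fare there.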